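Sulfamoylphenyl Replacing Aminofluoropyridinyl on the Shared Core

The source may hold more compounds than are shown below. What is called first, only, known or untested is meant among the compounds shown, and "the series" means these compounds.

Compound 1, `O=C(O)Cc1sc(C(c2ccc(F)cc2)c2ccc(F)cc2)nc1-c1ccnc(Cl)c1`: 80%
Compound 2, `Nc1cc(-c2nc(C(c3ccc(F)cc3)c3ccc(F)cc3)sc2CC(=O)O)cc(F)n1`: 30%

In an in vitro functional assay on HEK285-7 cells for antagonist activity at prostaglandin D2 receptor 2 (Homo sapiens), read by BRET and beta-arrestin recruitment (on this read-out lower numbers stand for smaller maximal responses and higher numbers for larger maximal responses), compound 1 gives 80%, while compound 2 gives 30%. For the measured compounds named here, compound 2 thus stands lowest of the two numbers; its only neighbour is compound 1, and the single measured step, a number 50 percentage points lower from compound 1 to compound 2 (beyond the scatter), is large and beyond the scatter.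

Compound 3, `NS(=O)(=O)c1cccc(-c2nc(C(c3ccc(F)cc3)c3ccc(F)cc3)sc2CC(=O)O)c1`, differs from compound 2 by 3-sulfamoylphenyl in place of 2-amino-6-fluoropyridin-4-yl on an aromatic carbon. Going by the values given here, the one step measured so far concerns the same position on the core and shows that exchanging the aromatic group there can move the maximal response widely. It does not show in which direction a 3-sulfamoylphenyl group would move it. Compound 3 is therefore expected to sit between the two measured numbers, with a wide range, amounting to an estimated step of a number 25 percentage points higher from compound 2 to compound 3 (beyond the scatter). For compound 3 the estimate is 55%, expected to fall between 20% and 90%.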

Compound 3, largest response reached (reported as efficacy), in percent of the reference or control that the assay uses: 55%
Compound 3: the middle estimate sits on the measured number at the digits printed, and the stated range covers the measured number.
By their numbers in this assay, from the lowest: compound 2; then compound 3; then compound 1.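

In this assay, the 3-sulfamoylphenyl group gives a number 25 percentage points higher from compound 2 to compound 3 (beyond the scatter), and a number 25 percentage points lower from compound 1 to compound 3 (beyond the scatter), so a ring of carbon only at this position gives a response inside the range set by the two pyridinyl compounds. The first of these steps also shows that the response can move beyond the scatter while the counts of hydrogen-bond donors and acceptors in the group stay the same, so those counts alone do not set the response across compound 2 and compound 3. Nothing available here explains why the response moves with these groups.

From the compounds shown here alone, what a methylsulfonyl group or a carboxylic acid would give in place of the sulfamoyl group stays open, as does the result for plain phenyl. Also open, going by these compounds, is whether 2-aminopyridin-4-yl, with the amine but no fluorine, would behave like the 2-amino-6-fluoropyridin-4-yl group.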